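Working notes: from compound 3 to compound 4

This account rests on a few compounds, and the source may have more. Where it says the series, first, only, none or still open, it means among the compounds named here.

Measured so far:
compound 1 `O=C(O)c1cnc(-c2ccccc2Cl)[nH]c1=O`: 5 mg/kg
compound 2 `CCOc1ccc(N(C)C)cc1-c1ncc(C(=O)O)c(=O)[nH]1`: 0.3 mg/kg
compound 3 `CCOC(=O)c1cnc(-c2ccccc2Cl)[nH]c1=O`: 5 mg/kg

In a functional assay on the whole organism (strain Sprague-Dawley) for inhibition, with Rattus norvegicus as the target, with a stated time of 10 min (a lower number here means that less compound is needed, a higher number that more compound is needed for the effect), compound 3 stands level with compound 1, together the highest of the three numbers; compound 2 shows a number well below both. Among the measured compounds shown here, the only measured step, no change at the digits printed from compound 1 to compound 3 (within the scatter), puts ethyl in place of hydrogen on an oxygen next to a carbonyl group. Compound 4 `CCOC(=O)c1cnc(-c2ccccc2OCC2CC2)[nH]c1=O` differs from compound 3 by cyclopropylmethoxy in place of chloro on an aromatic carbon. For the measured compounds named here, no measured step alters the substituent on the aromatic ring, so the ester step does not bear on this change; compound 2, which carries an ethoxy group on its aromatic ring, has the lowest number. For compound 4 a moderately lower number is expected, a step of a 2.5-fold lower number from compound 3 to compound 4 (0.40 log units; beyond the scatter), estimated at 2 mg/kg within 0.5 mg/kg to 8 mg/kg.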

Compound 4, dose for 50% inhibition: 0.3 mg/kg
Compound 4: middle estimate off by 6.7-fold (0.82 log units), on the high side; the measured number lies below the stated range.
By their numbers in this assay, from the lowest: compounds 2 and 4 (each within the scatter of the next); then compounds 1 and 3 (each within the scatter of the next).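

In this assay, among the compounds shown here, the change of cyclopropylmethoxy for chloro on an aromatic carbon gives a 17-fold lower number from compound 3 to compound 4 (1.22 log units; beyond the scatter) and is the first measured step at this position. Unlike the ester step, no change at the digits printed from compound 1 to compound 3 (within the scatter), this change moves the number well beyond the scatter, so the series responds strongly here. Nothing at hand accounts for the size of this step.

Going by these compounds, whether the drop follows the ether oxygen, the cyclopropyl ring or the larger group stays open; methoxy, a longer alkoxy chain or an amine here would separate these. On these data alone, how the free carboxylic acid behaves alongside cyclopropylmethoxy also remains open.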